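From Pyridin-3-ylmethyl to Benzyl: Expected Cytotoxicity

The compounds below may be only part of what the source reports. "The series", "measured", "known", "first", "only" and "open" are said of these compounds alone.

In an ADME assay (Homo sapiens) for cytotoxicity (on this read-out higher numbers stand for lower toxicity in this test and lower numbers for higher toxicity in this test), three compounds of one series have been measured, and none gave a number. Compound 1 `CC(=O)N1CCC(C(=O)N(CCCN2CCC(CNC(=O)c3cnccn3)CC2)c2ccc(C)c(Cl)c2)CC1` reached only a limit, > 52400 nM. Compound 2 `CC(=O)N1CCC(C(=O)N(CCCN2CCC(CNC(=O)c3ccsc3)CC2)c2ccc(C)c(Cl)c2)CC1` likewise reached only a limit, > 51900 nM. The step that the two limits leave unreadable from compound 1 to compound 2 thus has no readable size. Compound 3 `CC(=O)N1CCC(C(=O)N(CCCN2CCN(Cc3cccnc3)CC2)c2ccc(C)c(Cl)c2)CC1` also stands at a limit, > 56700 nM, so its position relative to the two others cannot be read. The evidence consists only of these limits: the limit of > 51900 nM in this assay, at which 1 of the 3 values shown sits, the limit of > 52400 nM in this assay, at which 1 of the 3 values shown sits, and (the limit of > 56700 nM in this assay, at which 1 of the 3 values shown sits).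

Compound 4 `CC(=O)N1CCC(C(=O)N(CCCN2CCN(Cc3ccccc3)CC2)c2ccc(C)c(Cl)c2)CC1` differs from compound 3 by phenyl in place of pyridin-3-yl on a saturated chain carbon bound to an amine nitrogen in a ring. Going by the values given here, no measured step bears directly on this change; the single step in hand is unreadable and concerns another part of the shared core. With all three measured compounds at their limits, compound 4 is expected to give 60000 nM in this assay, most probably again only a limit, within a range from 30000 nM to 150000 nM. The step that the limit leaves unreadable from compound 3 to compound 4 that this estimate implies is expected to stay within the scatter.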

Compound 4, half-maximal cytotoxic concentration: 101000 nM
The estimate for compound 4 lay 1.7-fold (0.23 log units) below the measured number; the range from low to high includes it.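

In this assay compound 3 gives only a limit, > 56700 nM. Compound 4 gives 101000 nM, yet the step from compound 3 to compound 4 cannot be read. The compounds shown leave open whether phenyl in place of pyridin-3-yl changes the half-maximal cytotoxic concentration at all.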